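The source may report more compounds than this note shows. Statements on the series, on what has been measured and on what is new or still open speak of the compounds shown alone.

Measured compounds and their values:

- compound 1, `O=c1ccoc2cc(OCc3cn(Cc4ccc(Cl)cc4Cl)nn3)ccc12`: > 300000 nM, a limit of the assay rather than a number
- compound 2, `O=c1ccoc2cc(OCc3cn(Cc4ccc(Br)cc4)nn3)ccc12`: > 300000 nM, again a limit
- compound 3, `O=c1ccoc2cc(OCc3cn(Cc4ccccc4Cl)nn3)ccc12`: > 300000 nM, again a limit

All three share one core and differ only in the ring carried on a saturated chain carbon bound to an aromatic nitrogen. In an ADME assay on L02 cells (Homo sapiens) for cytotoxicity, read by MTT assay, with a stated time of 48 h (on this read-out higher numbers stand for weaker inhibition and lower numbers for stronger inhibition), none of them gave a number; each stands at the limit of > 300000 nM in this assay, at which 3 of the 3 values shown sit, so the changes between them are not readable: a step that the two limits leave unreadable from compound 1 to compound 2, a step that the two limits leave unreadable from compound 1 to compound 3 and a step that the two limits leave unreadable from compound 2 to compound 3. Compound 3 therefore stands no lower and no higher than its two companions as far as the read-out can tell.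

Compound 4, `O=c1ccoc2cc(OCc3cn(Cc4ccccc4F)nn3)ccc12`, differs from compound 3 by fluoro in place of chloro on an aromatic carbon. Every measured step that bears on this position sits at the limit, so there is no ground to expect a step beyond the scatter; the estimated step of a number no higher from compound 3 to compound 4 (the limit leaves the size open) is none in either direction. Compound 4 is expected to give about 300000 nM in this assay, within a range of 100000 nM to 1000000 nM, most likely again reported only as a limit.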

Compound 4, half-maximal inhibitory concentration: > 300000 nM
Compound 4 was reported as a limit; the forecaster's own chance of this, stated with the estimate: 85%; the middle value sits exactly at the limit.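

In this assay compound 4 gives > 300000 nM, which is a limit and not a number. No step among compound 1, compound 2, compound 3 and compound 4 can be read: the limit of > 300000 nM in this assay, at which 4 of the 4 values shown sit.

The compounds shown leave open how these four rank against one another in this assay, and which change to the shared core, if any, would give a readable number.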